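Swapping the 4-hydroxycyclohexyl ether for a dinitrophenyl ether

The source may report more compounds than this note shows. Statements on the series, on what has been measured and on what is new or still open speak of the compounds shown alone.

In a functional assay on RS4-11 cells (Homo sapiens) for inhibition, read by CCK-8 assay, with a stated time of 48 h (a lower number here means a stronger inhibitor, a higher number a weaker inhibitor), compound 2 `O=C(NCCNS(=O)(=O)c1ccc(-c2ccccc2O[C@H]2CC[C@H](O)CC2)s1)Nc1ccc([N+](=O)[O-])cc1` gives 4100 nM, the lower of the two measured numbers. Its mirror image, compound 1 `O=C(NCCNS(=O)(=O)c1ccc(-c2ccccc2O[C@H]2CC[C@@H](O)CC2)s1)Nc1ccc([N+](=O)[O-])cc1`, gives 12400 nM. Compound 3 `O=C(NCCNS(=O)(=O)c1ccc(-c2ccccc2OCc2cccc(O)c2)s1)Nc1cc(Cl)cc(Cl)c1` returns only a limit, > 50000 nM. Compound 4 `O=C(NCCNS(=O)(=O)c1ccc(-c2ccccc2Oc2ccc([N+](=O)[O-])c([N+](=O)[O-])c2)s1)Nc1ccc([N+](=O)[O-])cc1` has 3,4-dinitrophenyl in place of 4-hydroxycyclohexyl on an oxygen on an aromatic ring. Among the compounds with values here, the only measured step, a 3.0-fold lower number from compound 1 to compound 2 (0.48 log units; beyond the scatter), changes configuration alone (the fact that compounds 1 and 2 differ only in the configuration as drawn), so it guides this replacement only loosely, though it shows that the number responds modestly to changes in the 4-hydroxycyclohexyl group. A modest move towards a higher number is therefore expected, a 2.2-fold higher number from compound 2 to compound 4 (0.34 log units; beyond the scatter), with wide uncertainty. Compound 4 is estimated at 9000 nM, within an expected range of 1500 nM to 40000 nM.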

Compound 4, half-maximal inhibitory concentration: 3000 nM
For compound 4 the middle estimate is 3.0-fold (0.48 log units) above the measured one, within the range that was stated.
By their numbers in this assay, from the lowest: compounds 4 and 2 (each within the scatter of the next); then compound 1. At a limit, above all of these: compound 3.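

In this assay the oxygen on the aromatic ring carries 3,4-dinitrophenyl, with no hydrogen-bond donor and no stereocentre, and the number stays level with that of compound 2 (a 1.4-fold lower number from compound 2 to compound 4 (0.14 log units; within the scatter)). The same replacement reads as a real gain when measured from the other isomer (a 4.1-fold lower number from compound 1 to compound 4 (0.62 log units; beyond the scatter)). Its apparent effect therefore depends on the starting compound, and those two starting compounds differ in one way only: the fact that compounds 1 and 2 differ only in the configuration as drawn.

As far as these compounds go, whether both nitro groups are needed remains open. So does how an aminocyclohexyl group or a benzoic acid on this oxygen would compare.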